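The source may report more compounds than this note shows. Statements on the series, on what has been measured and on what is new or still open speak of the compounds shown alone.

Compound 1 `COc1cc(-c2nn(-c3cccc(NC(=O)Nc4cc(C(F)(F)F)cc(C(F)(F)F)c4)c3)cc2-c2ccncc2)ccc1Cl` and compound 2 `O=C(Nc1cccc(-n2cc(-c3ccncc3)c(-c3ccc(Cl)c(O)c3)n2)c1)Nc1cc(C(F)(F)F)cc(C(F)(F)F)c1` differ only by hydrogen in place of methyl on an oxygen on an aromatic ring. In a functional assay on RPMI-8226 cells (Homo sapiens) for inhibition, read by sulforhodamine B assay, with a stated time of 48 h (on this read-out higher numbers stand for weaker inhibition of growth and lower numbers for stronger inhibition of growth), compound 1 gives 307 nM, and compound 2 gives 477 nM; the change made a 1.6-fold higher number from compound 1 to compound 2 (0.19 log units; within the scatter). Compound 3 `COc1cc(-c2nn(-c3cccc(NC(=O)Nc4ccc(Cl)c(C(F)(F)F)c4)c3)cc2-c2ccncc2)ccc1Cl` has another urea partner; the difference between the core of compound 3 and the core of compound 1 is not broken down here. In this assay compound 3 gives 868 nM, beyond the scatter from compound 1 and within it from compound 2. Compound 4 `O=C(Nc1cccc(-n2cc(-c3ccncc3)c(-c3ccc(Cl)c(O)c3)n2)c1)Nc1ccc(Cl)c(C(F)(F)F)c1` differs from compound 3 by hydrogen in place of methyl on an oxygen on an aromatic ring, at a place described in the same words as for compound 1 and compound 2, so the change is the same. The step in this assay is expected to be a 1.5-fold higher number from compound 3 to compound 4 (0.18 log units; within the scatter), a small one, because a 1.6-fold higher number from compound 1 to compound 2 (0.19 log units; within the scatter) stayed within the scatter. Compound 4 is therefore estimated at 1300 nM, likely between 600 nM and 2800 nM.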

Compound 4, concentration for 50% growth inhibition: 580 nM
Compound 4: the middle estimate sits 2.2-fold (0.35 log units) above what was measured; the whole stated range lies above it.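

In this assay, replacing methoxy with hydroxy on the core of compound 3 gives a 1.5-fold lower number from compound 3 to compound 4 (0.18 log units; within the scatter). Set beside the earlier step, the change shows no measurable difference between the two cores: the same change on two cores in this assay, a 1.6-fold higher number (0.19 log units; within the scatter) from compound 1 to compound 2 and a 1.5-fold lower number (0.18 log units; within the scatter) from compound 3 to compound 4, 2.3-fold (0.37 log units) apart, within the scatter of two such steps. For these two pairs the change carries across with no step beyond the scatter, but neither step establishes a direction, and two pairs in one assay cannot show how the change behaves on other cores or in other read-outs.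

The compounds shown leave open what an amine or a longer alkoxy chain would give in place of the methoxy. Also open, from the compounds shown here alone, is whether methoxy and hydroxy remain this close with urea partners other than those of compound 1 and compound 3.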